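The Step from Compound 3 to Compound 4

The compounds below may be only part of what the source reports. "The series", "measured", "known", "first", "only" and "open" are said of these compounds alone.

Measured so far:
compound 1 `Nc1cc(N)c2nc(-c3ccccc3)c(NCc3ccc(Cl)c(Cl)c3)nc2c1`: 95500 nM
compound 2 `Nc1cc(N)c2nc(-c3ccccc3)c(NCc3ccc(F)cc3)nc2c1`: < 100000 nM, a limit of the test
compound 3 `Nc1cc(N)c2nc(-c3ccccc3)c(Sc3ccc(Cl)c(Cl)c3)nc2c1`: < 100000 nM, a limit of the test

All three compounds were tested in a functional assay on NCI-H226 cells (Homo sapiens) for inhibition, read by sulforhodamine B assay, with a stated time of 48 h; on this read-out higher numbers stand for lower toxicity in this test and lower numbers for higher toxicity in this test. Among the compounds with values here, compound 1 is the only one with a number rather than a limit, and in this assay compound 1 gives 95500 nM. For compound 2 the result is only a limit. For compound 3 the result is likewise only a limit, so its place among the three cannot be fixed more closely than that.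

The step that the limit leaves unreadable from compound 1 to compound 2 cannot be read, and the same holds for a step that the two limits leave unreadable from compound 2 to compound 3, because of the limit of < 100000 nM in this assay, at which 2 of the 3 values shown sit.

Compound 4 `Nc1cc(N)c2nc(-c3ccccc3)c(Sc3ccc(F)cc3)nc2c1` differs from compound 3 by one change: 4-fluorophenyl in place of 3,4-dichlorophenyl on a sulfur. The two measured steps give no readable size for any change of this kind, so no shift beyond the scatter can be predicted from them. The step that the limit leaves unreadable from compound 3 to compound 4 is therefore expected to be small or none. Compound 4 is estimated to give about 90000 nM in this assay, with a range from 40000 nM to 100000 nM, and a good chance that only a limit is reported again.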

Compound 4, concentration lethal to 50% of the cells: < 100000 nM
Compound 4 ended at the assay's limit; the forecaster's own chance of this, stated with the estimate: 60%; the middle value does not contradict the limit.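

Compound 4 also ends at a limit, so no size can be read for the change from compound 3 to compound 4 or from compound 2 to compound 4, because these results are limits and not numbers: the limit of < 100000 nM in this assay, at which 3 of the 4 values shown sit.

The compounds shown leave open whether 4-fluorophenyl in place of 3,4-dichlorophenyl on a sulfur changes the result in this assay at all.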